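The compounds below may be only part of what the source reports. "The series", "measured", "known", "first", "only" and "open" are said of these compounds alone.

Measured so far:
- Compound 1 `Nc1nc(-c2ccc(Cl)cc2)c(CC(=O)O)s1` gives 50% in an in vitro functional assay on HEK285-7 cells for antagonist activity at prostaglandin D2 receptor 2 (Homo sapiens), read by BRET and beta-arrestin recruitment; a higher number here means a larger maximal response, a lower number a smaller maximal response.
- Compound 2 `O=C(O)Cc1sc(Cc2ccccc2)nc1-c1ccc(Cl)cc1` gives 50% in this assay.

Compound 2 stands level with compound 1 on the numbers shown. For the measured compounds named here, the one measured step, no change at the digits printed from compound 1 to compound 2 (within the scatter), brought benzyl in place of amino on an aromatic carbon and left the largest response unchanged within the scatter. So the two compounds measured to date cannot be ranked against each other; each reaches the same largest response on the numbers shown.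

Compound 3 `O=C(O)Cc1sc(C(Cc2ccccc2)c2ccccc2)nc1-c1ccc(Cl)cc1` is the next compound. It differs from compound 2 in one place:

benzyl in place of hydrogen on a saturated chain carbon bound to two aromatic carbons

Going by the values given here, the only step that bears on this change is the one from compound 1 to compound 2, where adding a benzyl group moved the largest response not at all beyond the scatter. Among the compounds with values here, the present change again adds a benzyl group, though at a different place, and nothing among the measured compounds points to a larger or smaller maximal response. The expectation for compound 3 is therefore a step of no change at the digits printed from compound 2 to compound 3 (within the scatter), that is, none beyond the scatter. Compound 3 is estimated to give 50%, with a range from 35% to 65%.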

Compound 3, largest response reached (reported as efficacy), in percent of the reference or control that the assay uses: 50%
Compound 3: the middle estimate sits on the measured number at the digits printed; the measured number falls inside the stated range.
By their numbers in this assay, from the lowest: compounds 1, 2 and 3 (each within the scatter of the next).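

In this assay, benzyl in place of hydrogen on a saturated chain carbon bound to two aromatic carbons gives no change at the digits printed from compound 2 to compound 3 (within the scatter) even though the entering group brings 7 heavy atoms and one six-membered aromatic ring of carbon only. The earlier step, no change at the digits printed from compound 1 to compound 2 (within the scatter) placed benzyl on an aromatic carbon, so this result adds a second place, the saturated chain carbon, at which a benzyl group leaves the largest response within the scatter across these compounds. No measurement is available that would explain why the largest response holds at this position.

From the compounds shown here alone, it remains open whether a hydroxyl group or an amine on the same chain carbon, or a longer chain such as 2-phenylethyl in place of benzyl, would give a different largest response. The three compounds also share the rest of the core, including the carboxylic acid, so they say nothing about how an amide or another group at that place would read out in this assay.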